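Changing the amide aryl group of compound 2

The source may hold more compounds than are shown below. What is called first, only, known or untested is meant among the compounds shown, and "the series" means these compounds.

Measured in a functional assay on A549 cells (Homo sapiens) for cytotoxicity, read by MTT assay, with a stated time of 72 h; on this read-out lower numbers stand for stronger inhibition and higher numbers for weaker inhibition
- compound 1 `O=C(CN1CCN(c2nnc(Cc3ccncc3)c3ccccc23)CC1)Nc1cccc(F)c1` gives 4600 nM as its value
- compound 2 `O=C(CN1CCN(c2nnc(Cc3ccncc3)c3ccccc23)CC1)Nc1cc(C(F)(F)F)ccc1Cl` gives 1850 nM as its value

Compound 2 has the lower of these two numbers. Compound 3 `O=C(CN1CCN(c2nnc(Cc3ccncc3)c3ccccc23)CC1)Nc1c(F)cccc1F` has not been measured and carries 2,6-difluorophenyl in place of 2-chloro-5-(trifluoromethyl)phenyl on an amide-type nitrogen in that one place. Within the data shown here, the only measured step at this place is a 2.5-fold lower number from compound 1 to compound 2 (0.40 log units; beyond the scatter) on the same nitrogen. The entering group carries only fluorine, like the 3-fluorophenyl of compound 1 at 4600 nM in this test, so a modest move to a higher number is expected in this assay here. The expected change is a 2.2-fold higher number from compound 2 to compound 3 (0.33 log units; beyond the scatter) by this estimate. For compound 3 the estimated value is 4000 nM with an expected range of 1700 nM to 9000 nM overall.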

Compound 3, half-maximal inhibitory concentration: 54400 nM
The estimate for compound 3 lay 14-fold (1.13 log units) below the measured number, and the stated range ends below it.
By their numbers in this assay, from the lowest: compound 2; then compound 1; then compound 3.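

In this assay the aryl group on the amide nitrogen can matter far more than the first pair suggested, with a 29-fold higher number from compound 2 to compound 3 (1.47 log units; beyond the scatter) and a 12-fold higher number from compound 1 to compound 3 (1.07 log units; beyond the scatter) on the same nitrogen. Carrying only fluorine does not settle the level, as compound 1 and compound 3 both do so and still differ widely. Nothing available explains this drop.

These three aryl groups differ in several ways at once, so the contributions of the chlorine, the trifluoromethyl and each fluorine remain unseparated. Also open, as far as these compounds go, is how an unsubstituted phenyl or a methoxyphenyl would fit into this order.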